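From 2-chlorophenyl to 4-methylphenyl on a shared core

The compounds below may be only part of what the source reports. "The series", "measured", "known", "first", "only" and "open" are said of these compounds alone.

Compound 1 `C[C@H]1CC[C@@H]2[C@@H](OC(=O)[C@]23CC(c2ccc(Cl)cc2)=NO3)[C@]2(C)C(=O)C=C[C@@]12O` gives 49000 nM
Compound 2 `COc1cc(C2=NO[C@]3(C2)C(=O)O[C@@H]2[C@H]3CC[C@H](C)[C@]3(O)C=CC(=O)[C@@]23C)ccc1O` gives 16000 nM
Compound 3 `C[C@H]1CC[C@@H]2[C@@H](OC(=O)[C@]23CC(c2ccccc2Cl)=NO3)[C@]2(C)C(=O)C=C[C@@]12O` gives 12000 nM

These three compounds share one core and differ only in the aromatic group attached to it. Compound 3 sits at the low end of the numbers in a functional assay on PC-3 cells (Homo sapiens) for cytotoxicity, read by sulforhodamine B assay, with a stated time of 48 h (on this read-out higher numbers stand for weaker inhibition and lower numbers for stronger inhibition), without a clear lead: the gap to its nearest neighbour is a 1.3-fold lower number from compound 2 to compound 3 (0.12 log units; within the scatter) here.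

Compound 4 `Cc1ccc(C2=NO[C@]3(C2)C(=O)O[C@@H]2[C@H]3CC[C@H](C)[C@]3(O)C=CC(=O)[C@@]23C)cc1` has not been measured yet. Its change is 4-methylphenyl in place of 2-chlorophenyl on a carbon with a double bond to nitrogen and nothing else in the structure differs.

Two measured steps at this same place bear on it. The closer one is a 4.1-fold lower number from compound 1 to compound 3 (0.61 log units; beyond the scatter) and it shows that 2-chlorophenyl gave a lower number than 4-chlorophenyl. The other is a 3.1-fold lower number from compound 1 to compound 2 (0.49 log units; beyond the scatter) and it is of similar size. Among the measured compounds shown here, the entering 4-methylphenyl resembles the 4-chlorophenyl of compound 1 by name, but no measured compound carries a methyl group, so this guide is weak. What is expected in this assay is therefore a modest step toward higher numbers, estimated as a 2.1-fold higher number from compound 3 to compound 4 (0.32 log units; beyond the scatter) at the middle. The estimate for compound 4 is 25000 nM with an expected range of 10000 nM to 60000 nM in this read-out.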

Compound 4, half-maximal inhibitory concentration: 14000 nM
Beside the measured number, compound 4's estimate is 1.8-fold (0.25 log units) above it; the measured number falls inside the stated range.
By their numbers in this assay, from the lowest: compounds 3, 4 and 2 (each within the scatter of the next); then compound 1.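

In this assay, the 4-methylphenyl group cannot be told apart from the two groups that gave the lowest earlier numbers: a 1.2-fold higher number from compound 3 to compound 4 (0.07 log units; within the scatter) and a 1.1-fold lower number from compound 2 to compound 4 (0.06 log units; within the scatter) both leave compound 4 level with its neighbours, so these three compounds have no order among them. Among the compounds shown here, the informative comparison is the single swap of methyl for chloro on an aromatic carbon, with a 3.5-fold lower number from compound 1 to compound 4 (0.54 log units; beyond the scatter) lying beyond the scatter. Before this result, the gap between compound 1 and compound 3 could have been read as a general penalty for any group at the 4 position of the phenyl ring, but compound 4 carries such a group and still groups with compound 2 and compound 3, which leaves compound 1 alone at the high end. No measurement of any property of these groups is available to explain this step.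

On these data alone, whether a 2-methylphenyl group would match the 2-chlorophenyl of compound 3 remains open, as does whether the 4-chlorophenyl result is specific to chlorine or would be shared by 4-bromophenyl. A ring carrying an amine or a carboxylic acid, or a saturated cyclohexyl group in place of the aromatic ring, is also untested among the compounds shown here.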